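The source may hold more compounds than are shown below. What is called first, only, known or untested is meant among the compounds shown, and "the series" means these compounds.

Working notes on the series. Among the measured compounds shown here, compound 1 `Nc1nc(Cl)c2ncn(Cc3ccccc3CCl)c2n1` is the one member with a numeric value: in a functional assay on SF-268 cells (Homo sapiens) for cytotoxicity, read by sulforhodamine B assay, with a stated time of 48 h (a lower number here means that less compound is tolerated, a higher number that more compound is tolerated), compound 1 gives 97200 nM, close to the upper edge of the tested range. Compound 2 `ClCc1ccccc1Cn1cnc2ncnc(Cl)c21` is recorded only as a limit of this assay, with compound 2 giving > 100000 nM and no number (the limit of > 100000 nM in this assay, at which 1 of the 2 values shown sits). For the measured compounds named here, no step between two measured compounds is available.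

Compound 3 `ClCc1ccccc1Cn1cnc2c(Cl)ncnc21` differs from compound 1 by one change, (hydrogen in place of amino on an aromatic carbon), on an aromatic carbon of the six-membered ring that sits between two ring nitrogen atoms. The amino group leaving takes away one hydrogen-bond donor and one acceptor. Compound 1 gives 97200 nM in this assay, and for this change no move beyond the usual scatter is expected in either direction. Compound 3 is therefore estimated at 120000 nM, with a range of 60000 nM to 300000 nM, which means an expected step from compound 1 to compound 3 of a 1.2-fold higher number from compound 1 to compound 3 (0.09 log units; within the scatter).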

Compound 3, concentration lethal to 50% of the cells: > 100000 nM
Compound 3: only a limit was reported (the forecaster's own chance of this, stated with the estimate: 60%); the middle value lies beyond the limit too.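

At the aromatic carbon between two ring nitrogen atoms, hydrogen in place of amino gives an at least 1.0-fold higher number from compound 1 to compound 3 (0.01 log units; that floor lies within the scatter) in this assay. Among the compounds shown here, this is the first step, and it shows no fall in the number when the amino group leaves, though the printed floor does not settle whether the true rise lies beyond the scatter. The step can be read only as a floor because compound 3 is recorded as a limit and not a number: the limit of > 100000 nM in this assay, at which 2 of the 3 values shown sit.

Going by these compounds, how far the number rises from compound 1 to compound 3 stays open, as does whether the amino group has any real part in the value of compound 1. Also open, on these data alone, is what a methylamino, hydroxyl or methyl group on that same carbon would give in this assay.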